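From fluoro to bromo on a compound at the limit

This account rests on a few compounds, and the source may have more. Where it says the series, first, only, none or still open, it means among the compounds named here.

Among the measured compounds shown here, in a toxicity assay on THP-1 cells (Homo sapiens) for cytotoxicity, read by MTT assay (a higher number here means a weaker inhibitor of growth, a lower number a stronger inhibitor of growth), only one of the measured compounds has a true number: compound 1 `C/C(=N\NC(N)=S)c1sc(-c2ccccc2)nc1C` gives 81.5 ug/mL. Compound 2 `C/C(=N\Nc1nc(-c2ccccc2)cs1)c1sc(C)nc1C` reads > 100 ug/mL, which is a limit and not a number. Compound 3 `C/C(=N\Nc1nc(-c2ccc(F)cc2)cs1)c1sc(C)nc1C` reads > 100 ug/mL, which is also a limit and not a number. Compound 3 therefore has no exact place on the scale.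

Compound 4 `C/C(=N\Nc1nc(-c2ccc(Br)cc2)cs1)c1sc(C)nc1C` differs from compound 3 by one swap, bromo in place of fluoro on an aromatic carbon, para to a large group, so that 4-fluorophenyl becomes 4-bromophenyl.

For the measured compounds named here, one measured step bears on this swap, the change of hydrogen to fluoro at an aromatic carbon. It is a step that the two limits leave unreadable from compound 2 to compound 3, so it offers no size to carry over. What remains is the limit of > 100 ug/mL in this assay, at which 2 of the 3 values shown sit. On that basis, no step beyond the scatter is expected in this assay, and no direction can be given. The expected step is a number no higher from compound 3 to compound 4 (the limit leaves the size open). For compound 4 the estimate is 100 ug/mL, with an expected range from 50 ug/mL to 200 ug/mL, and a report of only a limit would be no surprise.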

Compound 4, concentration for 50% growth inhibition: > 100 ug/mL
Compound 4: a limit, no number; the forecaster's own chance of this, stated with the estimate: 65%; the middle value sits exactly at the limit.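

Among the compounds shown here, compound 2, compound 3 and compound 4 each give only a limit in this assay, so no step among them can be read. All three share one reading: the limit of > 100 ug/mL in this assay, at which 3 of the 4 values shown sit. The compounds shown leave open whether hydrogen, fluoro and bromo at this place differ at all in their inhibition of growth.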